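Swapping the methylphenyl arm for a pyridine

The source may report more compounds than this note shows. Statements on the series, on what has been measured and on what is new or still open speak of the compounds shown alone.

Compound 2 `Cc1ccc(CN(Cc2ccc(C(=O)NO)cc2)S(=O)(=O)c2c(F)c(F)c(F)c(F)c2F)cc1` gives 6 nM in an assay on isolated protein for inhibition of protein deacetylase HDAC6 (Homo sapiens), read by mobility shift assay (on this read-out higher numbers stand for weaker inhibition and lower numbers for stronger inhibition), the lower of the two numbers measured, with compound 1 `O=C(NO)c1ccc(CN(Cc2ccc(C(F)(F)F)cc2)S(=O)(=O)c2c(F)c(F)c(F)c(F)c2F)cc1` at 45 nM. Among the measured compounds shown here, the only step available, a 7.5-fold lower number from compound 1 to compound 2 (0.88 log units; beyond the scatter), shows that changing the group on this aromatic ring moves the number well beyond the scatter. Compound 3 `O=C(NO)c1ccc(CN(Cc2ccncc2)S(=O)(=O)c2c(F)c(F)c(F)c(F)c2F)cc1` carries the change (pyridin-4-yl in place of 4-methylphenyl on a saturated chain carbon bound to a sulfonamide nitrogen). For the measured compounds named here, no measured step shows a pyridine entering here, so a weaker result is expected by analogy, with a step of a 3.3-fold higher number from compound 2 to compound 3 (0.52 log units; beyond the scatter) estimated. Compound 3 is therefore estimated at 20 nM, in the range 6 nM to 70 nM.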

Compound 3, half-maximal inhibitory concentration: 14 nM
Beside the measured number, compound 3's estimate is 1.4-fold (0.15 log units) above it; the range from low to high includes it.
By their numbers in this assay, from the lowest: compound 2; then compound 3; then compound 1.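

In this assay, this position accepts a ring holding a nitrogen: pyridin-4-yl in place of 4-methylphenyl gives a 2.3-fold higher number from compound 2 to compound 3 (0.37 log units; beyond the scatter). Set against 4-(trifluoromethyl)phenyl, the same ring gives a 3.2-fold lower number from compound 1 to compound 3 (0.51 log units; beyond the scatter), so the pyridine's number lies inside the span set by the two substituted phenyl arms, and changing the whole ring moves the number here, not only changing its substituent. Nothing measured here explains these shifts. Still open, as far as these compounds go, are how pyridin-3-yl would compare with pyridin-4-yl, and what an amine or a carboxylic acid on this ring would do.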